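A few compounds are considered here, and "the series" means these few. Any claim that something is new, unique, unknown or untested is made for them only; others in the source may bear on it.

Measured compounds:
compound 1, `CCC1(CCCCN2CCN(c3cccc(Cl)c3)CC2)C(=O)Nc2ccccc21`, 0.41 nM;
compound 2, `CCC1(CCCCN2CCN(c3ccc(F)cc3)CC2)C(=O)Nc2ccccc21`, 0.43 nM;
compound 3, `O=C1Nc2ccc(F)cc2C1CCCCN1CCN(c2cccc(Cl)c2)CC1`, 1.96 nM.

All three were tested in an assay on CHO cells for displacement of a labelled ligand from 5-hydroxytryptamine receptor 7 (Homo sapiens); a lower number here means a stronger inhibitor, a higher number a weaker inhibitor. Compound 1 and compound 2 share a core and differ only in the group on the ring nitrogen, as counted here: 4-fluorophenyl in place of 3-chlorophenyl on an amine nitrogen in a ring. That change made the step of a 1.0-fold higher number from compound 1 to compound 2 (0.02 log units; within the scatter), so the two values cannot be told apart. Compound 3 carries a different core; how its core differs from that of compound 1 is not broken down here. Its value in this assay stands highest of the three, beyond the scatter of both compound 1 and compound 2.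

Compound 4, `O=C1Nc2ccc(F)cc2C1CCCCN1CCN(c2ccc(F)cc2)CC1`, has not yet been measured in this assay. It stands to compound 3 exactly as compound 2 stands to compound 1: 4-fluorophenyl in place of 3-chlorophenyl on an amine nitrogen in a ring. For the measured compounds named here, this is the same change, at the same place, as the one between compound 1 and compound 2. Since that earlier step lay within the scatter, compound 4 is expected to sit close to compound 3, with an estimated step of a 1.0-fold higher number from compound 3 to compound 4 (0.01 log units; within the scatter). The estimate for compound 4 in this assay is 2 nM, expected to fall between 1 nM and 4 nM.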

Compound 4, inhibition constant: 3.4 nM
Compound 4: middle estimate off by 1.7-fold (0.23 log units), on the low side; the range from low to high includes it.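

In this assay, the new step is a 1.7-fold higher number from compound 3 to compound 4 (0.24 log units; within the scatter), so on this core too, 4-fluorophenyl in place of 3-chlorophenyl gives values that cannot be told apart. Set beside the earlier step, the change carries from one core to the other with no difference that can be resolved: the same change on two cores in this assay, a 1.0-fold higher number (0.02 log units; within the scatter) from compound 1 to compound 2 and a 1.7-fold higher number (0.24 log units; within the scatter) from compound 3 to compound 4, 1.7-fold (0.22 log units) apart, within the scatter of two such steps. This shows agreement for one change on two cores, with a single pair on each and in one assay, but it does not show that the change would behave alike on any further core, and it gives no reason for the agreement.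

The compounds shown leave open whether other groups on the same amine nitrogen, such as an unsubstituted phenyl, a pyridyl or a benzyl group, would also carry from core to core in this way. They also leave open whether the same would hold with a longer chain in place of the present one, or on a core with an amine or a carboxylic acid added.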